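The source may hold more compounds than are shown below. What is called first, only, known or untested is meant among the compounds shown, and "the series" means these compounds.

Measured compounds:
compound 1, `Oc1ccc(-c2cc(-c3ccco3)nc(-c3ccccc3Cl)c2)cc1`, 3.9%
compound 2, `Oc1ccc(-c2cc(-c3ccsc3)nc(-c3ccccc3Cl)c2)cc1`, 4.1%
compound 3, `Oc1cccc(-c2cc(-c3ccsc3)nc(-c3ccccc3Cl)c2)c1`, 0%

All three were tested in an assay on isolated protein for inhibition of DNA topoisomerase 1 (Homo sapiens), with a stated time of 30 min, tested at 100 uM; a lower number here means a weaker effect, a higher number a stronger effect of the compound at the concentration tested. In this assay compound 1 gives 3.9%, compound 2 gives 4.1% and compound 3 gives 0%; the three numbers sit together within the usual scatter, so no order among them can be read from these data.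

Compound 2 and compound 1 differ in one place: furan-2-yl in place of thiophen-3-yl on an aromatic carbon. This change made the step of a number 0.2 percentage points lower from compound 2 to compound 1 (within the scatter). Compound 2 and compound 3 share the same atoms joined differently; their cores differ as follows: 3-hydroxyphenyl in place of 4-hydroxyphenyl on an aromatic carbon. That change made the step of a number 4.1 percentage points lower from compound 2 to compound 3 (within the scatter).

Compound 4, `Oc1cccc(-c2cc(-c3ccco3)nc(-c3ccccc3Cl)c2)c1`, has not yet been measured. It differs from compound 3 in the same kind of change as that from compound 2 to compound 1: furan-2-yl in place of thiophen-3-yl on an aromatic carbon. The surroundings of the place are not the same word for word: in compound 2 the exchanged group sits meta to a 4-hydroxyphenyl group, in compound 3 meta to a 3-hydroxyphenyl group.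

Because the earlier step of a number 0.2 percentage points lower from compound 2 to compound 1 (within the scatter) lay within the scatter, and because compound 3 stands at 0%, compound 4 is expected to show a step of about a number 1 percentage points higher from compound 3 to compound 4 (within the scatter). Compound 4 is therefore estimated at 1%, within a range from 0% to 10%.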

Compound 4, a percentage reported as inhibition, at one concentration (the size of the read-out at that concentration, not a potency): 0%
The estimate for compound 4 lay 1 percentage points above the measured number; the range from low to high includes it.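

In this assay, furan-2-yl in place of thiophen-3-yl on the core bearing the 3-hydroxyphenyl group gave no change at the digits printed from compound 3 to compound 4 (within the scatter), and this agrees with the same exchange on the core bearing the 4-hydroxyphenyl group: the same change on two cores in this assay, a number 0.2 percentage points lower (within the scatter) from compound 2 to compound 1 and no change at the digits printed (within the scatter) from compound 3 to compound 4, 0.2 percentage points apart, within the scatter of two such steps

With furan-2-yl held in place, 3-hydroxyphenyl in place of 4-hydroxyphenyl gave a number 3.9 percentage points lower from compound 1 to compound 4 (within the scatter), which likewise agrees with the step seen with thiophen-3-yl: the same change on two cores in this assay, a number 4.1 percentage points lower (within the scatter) from compound 2 to compound 3 and a number 3.9 percentage points lower (within the scatter) from compound 1 to compound 4, 0.2 percentage points apart, within the scatter of two such steps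

Among these compounds, this shows that, across these four compounds, neither change moved the read-out beyond the scatter on either core, but every step is too small to tell from no step at all, so the agreement does not show that a real effect of either change carries from one core to another, nor that the two rings or the two hydroxyphenyl groups are equivalent at this target.

The compounds shown leave open what an amine or a carboxylic acid would do at the place of the five-membered ring, or a methoxy group in place of the hydroxyl. They also leave open whether a different group in place of the 2-chlorophenyl group would lift the series to a read-out large enough for such steps to be compared.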